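Series notes: methyl on the aromatic oxygen, compound 3

The source may hold more compounds than are shown below. What is called first, only, known or untested is meant among the compounds shown, and "the series" means these compounds.

Within the data shown here, in a functional assay on UACC-257 cells (Homo sapiens) for inhibition, read by sulforhodamine B assay, with a stated time of 48 h, tested at 10 uM (on this read-out higher numbers stand for a weaker effect at the one concentration tested and lower numbers for a stronger effect), compound 2 `O=C(Nc1cccc(-n2cc(-c3ccncc3)c(-c3cc(O)cc(Cl)c3)n2)c1)Nc1ccc(Cl)c(Cl)c1` gives -70.7%, the lowest of the two numbers measured so far. Among the measured compounds shown here, compound 1 `O=C(Nc1cccc(-n2cc(-c3ccncc3)c(-c3cc(O)cc(Cl)c3)n2)c1)Nc1ccc(Cl)c(C(F)(F)F)c1` gives -40% in this assay, and the step of a number 30.7 percentage points lower from compound 1 to compound 2 (beyond the scatter) is the only measured step in the set, a chloro in place of trifluoromethyl on an aromatic carbon. Compound 3 `COc1cc(Cl)cc(-c2nn(-c3cccc(NC(=O)Nc4ccc(Cl)c(Cl)c4)c3)cc2-c2ccncc2)c1`, not yet measured, differs from compound 2 by methyl in place of hydrogen on an oxygen on an aromatic ring, read one bond further out as hydroxy to methoxy, 3-chloro-5-hydroxyphenyl to 3-chloro-5-methoxyphenyl. For the measured compounds named here, no measured step touches this oxygen, so the single measured step does not bear on the change, and nothing measured says how the methyl will read. The step of a number 8.7 percentage points higher from compound 2 to compound 3 (within the scatter) is therefore expected to stay within the scatter, with wide uncertainty. Compound 3 in this assay is estimated at -62%, with a range from -88% to -30%.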

Compound 3, a percentage reported as activity, at one concentration (the size of the read-out at that concentration, not a potency): -11.5%
Compound 3: middle estimate off by 50.5 percentage points, on the low side; the measured number lies above the stated range.
By their numbers in this assay, from the lowest: compound 2; then compound 1; then compound 3.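

In this assay, methyl in place of hydrogen on an oxygen on an aromatic ring gives a number 59.2 percentage points higher from compound 2 to compound 3 (beyond the scatter), so the effect at the one concentration tested is much weaker with methoxy than with hydroxy. Among these compounds, this is the first measured change on the 3-chloro-5-hydroxyphenyl group, and it shows that the read-out is not indifferent to what sits on this oxygen. Nothing at hand gives a reason for the size of this step.

This single pair cannot separate the loss of the hydrogen from the arrival of the methyl, and an amino group or a fluoro in place of the hydroxy would bear on that question. From the compounds shown here alone, it also remains open whether a longer ether such as ethoxy reads like methoxy, and whether the same step holds with the trifluoromethyl group of compound 1.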